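The source may report more compounds than this note shows. Statements on the series, on what has been measured and on what is new or still open speak of the compounds shown alone.

Measured compounds:
compound 1, `CCCc1nc(-c2ccccc2)c(CNCCN2CCN(c3ccccc3F)CC2)o1`, 46.5%
compound 2, `CCCc1nc(-c2ccccc2)c(CNCCCN2CCN(c3ccc(C(F)(F)F)cc3)CC2)o1`, 51.6%
compound 3, `CCCc1nc(-c2ccccc2)c(CNCCCN2CCN(c3cccc(C)c3C)CC2)o1`, 55.2%

In an assay on HEK293 cells for inhibition of Voltage-dependent T-type calcium channel subunit alpha-1G (Homo sapiens), read by fluorescence, tested at 10 uM (on this read-out higher numbers stand for more inhibition at the one concentration tested (going by the name of the read-out) and lower numbers for less inhibition), compound 1 gives the lowest of the three numbers shown, but its gap to compound 2 and its gap to compound 3 are both within the usual scatter, so the three are not told apart by this read-out. The next compound is compound 4, `CCCc1nc(-c2ccccc2)c(CNCCN2CCN(c3ccc(C(F)(F)F)cc3)CC2)o1`, which differs from compound 1 only at one place: 4-(trifluoromethyl)phenyl in place of 2-fluorophenyl on an amine nitrogen in a ring. Within the data shown here, the only measured step that bears on this change is the exchange of one aryl group for another on the same ring nitrogen, a number 3.6 percentage points higher from compound 2 to compound 3 (within the scatter), which stayed within the scatter. Among the measured compounds shown here, compound 2 and compound 3 differ from compound 4 elsewhere in the molecule, and no measured step joins compound 1 directly to compound 2 or compound 4, so only the three values themselves, all close together, give further guidance. The step from compound 1 to compound 4 is therefore expected to be small, a number 3.5 percentage points higher from compound 1 to compound 4 (within the scatter), with no direction beyond the scatter. Compound 4 is estimated at 50%, between 35% and 65%.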

Compound 4, a percentage reported as inhibition, at one concentration (the size of the read-out at that concentration, not a potency): 58.7%
For compound 4 the middle estimate is 8.7 percentage points below the measured one; the range from low to high includes it.
By their numbers in this assay, from the lowest: compounds 1, 2, 3 and 4 (each within the scatter of the next, the first and the last beyond it).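

In this assay, among these compounds, the swap of 2-fluorophenyl for 4-(trifluoromethyl)phenyl gives a number 12.2 percentage points higher from compound 1 to compound 4 (beyond the scatter) and so is the first step here to clear the usual scatter. The earlier aryl exchange, a number 3.6 percentage points higher from compound 2 to compound 3 (within the scatter), stayed inside it, so the aryl group on this amine nitrogen in a ring can move the read-out by a modest amount, at least with the linking chain shared by compound 1 and compound 4. Nothing measured here explains this gain.

This step changes both the substituent and its place on the phenyl ring, and the compounds shown do not separate the two. A 4-fluorophenyl or a 2-(trifluoromethyl)phenyl group would be needed to tell them apart, and a pyridine ring would test whether a carbon-only aromatic ring is needed at all.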